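Methoxy added to a weak benzylamine series

The source may report more compounds than this note shows. Statements on the series, on what has been measured and on what is new or still open speak of the compounds shown alone.

Three compounds share one core, a quinazoline-like scaffold carrying a benzylamine arm, and were tested in a functional assay on CCRF-CEM cells (Homo sapiens) for cytotoxicity, read by MTT assay, with a stated time of 72 h; on this read-out higher numbers stand for weaker inhibition of growth and lower numbers for stronger inhibition of growth. Compound 1 `COc1ccc(CNc2nc([SeH])nc3ccccc23)cc1` gives only a limit of the assay, > 100000 nM. Compound 2 `CSc1nc(NCc2ccc([Se]C)cc2)c2ccccc2n1` gives 63300 nM. Compound 3 `CSc1nc(NCc2ccccc2)c2ccccc2n1` gives 87900 nM, the highest of the two numbers, with compound 2 nearest and within the scatter. For the measured compounds named here, the single measured step, a 1.4-fold higher number from compound 2 to compound 3 (0.14 log units; within the scatter), shows that removing the methylselanyl group from the benzyl ring leaves growth inhibition essentially unchanged.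

Compound 4 `COc1ccc(CNc2nc(SC)nc3ccccc23)cc1` is the next step from compound 3: methoxy in place of hydrogen on an aromatic carbon. Going by the values given here, no measured step adds a methoxy group here, so nothing directly tells how large this change should be. Compound 1 also carries the methoxy group but differs from compound 4 at the core as well, and it gives only a limit, which offers little guidance. The change resembles the measured step in being a small substituent on the benzyl ring, which moved the number only within the scatter. The step from compound 3 to compound 4 is therefore expected to be small, a 1.0-fold higher number from compound 3 to compound 4 (0.01 log units; within the scatter). For compound 4 the estimate in this assay is 90000 nM, with a range from 40000 nM to 200000 nM.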

Compound 4, concentration for 50% growth inhibition: 93700 nM
Compound 4: the middle estimate sits 1.0-fold (0.02 log units) below what was measured; the measured number falls inside the stated range.
By their numbers in this assay, from the lowest: compounds 2, 3 and 4 (each within the scatter of the next). At a limit, above all of these: compound 1.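

Putting a methoxy group on the aromatic carbon para to a large group, where compound 3 carries only hydrogen, gives a 1.1-fold higher number from compound 3 to compound 4 (0.03 log units; within the scatter) in this assay, so this first direct test of the change finds no effect beyond the scatter. Exchanging methylselanyl for methoxy at that same place gives a 1.5-fold higher number from compound 2 to compound 4 (0.17 log units; within the scatter), so hydrogen, methoxy and methylselanyl there cannot be told apart in this read-out. Compound 1 stands at a limit, and an at least 1.0-fold lower number from compound 1 to compound 4 (0.02 log units; that floor lies within the scatter) is only a floor, which says little about exchanging the selenium atom on the core for the sulfur-bearing group.

As far as these compounds go, whether an amine, a carboxylic acid or a longer chain at this place would shift growth inhibition beyond the scatter remains open. Also open, from the compounds shown here alone, is whether any change to this ring can bring the numbers far lower.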